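The compounds below may be only part of what the source reports. "The series", "measured", "known", "first", "only" and "open" are said of these compounds alone.

The compounds measured in a functional assay on HT-29 cells (Homo sapiens) for cytotoxicity, read by MTT assay, with a stated time of 72 h (on this read-out lower numbers stand for stronger inhibition and higher numbers for weaker inhibition), are:

compound 1, `COc1cc2c(Oc3ccc(NC(=O)c4cn(-c5cc(C)ccc5C)cn4)cc3F)ccnc2cc1OCCCN1CCN(C)CC1`, giving 470 nM;
compound 2, `COc1cc2c(Oc3ccc(NC(=O)c4cn(-c5cc(C)ccc5C)cn4)cc3F)ccnc2cc1OCCCN1CCCCC1`, giving 580 nM;
compound 3, `COc1cc2c(Oc3ccc(NC(=O)/C=C/S(=O)(=O)c4ccccc4OC)cc3F)ccnc2cc1OCCCN1CCN(C)CC1`, giving 270 nM.

Compound 1 and compound 2 share one core and differ only in the change (piperidin-1-yl in place of 4-methylpiperazin-1-yl on a saturated chain carbon, three bonds along the chain from an oxygen on an aromatic ring). That change made the step of a 1.2-fold higher number from compound 1 to compound 2 (0.09 log units; within the scatter). Compound 3 has a different core; the difference between the two cores is not broken down here. In this assay compound 3 has the lowest number of the three, but its gap to compound 1 is within the scatter, so no order between them can be claimed.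

Compound 4, `COc1cc2c(Oc3ccc(NC(=O)/C=C/S(=O)(=O)c4ccccc4OC)cc3F)ccnc2cc1OCCCN1CCCCC1`, has not yet been measured. It differs from compound 3 by piperidin-1-yl in place of 4-methylpiperazin-1-yl on a saturated chain carbon, three bonds along the chain from an oxygen on an aromatic ring, and the place of the change is given in the same words as for compound 1 and compound 2, so it is the same change. Because the earlier step of a 1.2-fold higher number from compound 1 to compound 2 (0.09 log units; within the scatter) was small, the step from compound 3 to compound 4 is expected to be small as well, estimated as a 1.2-fold higher number from compound 3 to compound 4 (0.07 log units; within the scatter). Compound 4 is therefore estimated at 320 nM in this assay, most likely between 160 nM and 650 nM.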

Compound 4, half-maximal inhibitory concentration: 660 nM
For compound 4 the middle estimate is 2.1-fold (0.31 log units) below the measured one; the whole stated range lies below it.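

In this assay, putting piperidin-1-yl in place of 4-methylpiperazin-1-yl on the core of compound 3 gave a 2.4-fold higher number from compound 3 to compound 4 (0.39 log units; beyond the scatter), a step beyond the scatter, whereas the same change on the core of compound 1 stayed within the scatter. Taken alone, these results might suggest that the change matters more on one core than on the other, but comparing the two steps directly does not support that reading: the same change on two cores in this assay, a 1.2-fold higher number (0.09 log units; within the scatter) from compound 1 to compound 2 and a 2.4-fold higher number (0.39 log units; beyond the scatter) from compound 3 to compound 4, 2.0-fold (0.30 log units) apart, within the scatter of two such steps The result therefore does not show that the core alters the effect of this change, nor does it prove that the effect is identical on both cores, as each core offers only one pair of compounds.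

The compounds shown leave open how a morpholin-4-yl or dimethylamino group would compare at the same place on either core. They also leave open whether the step would stay similar with a butyl chain in place of the propyl chain, or on a third core.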